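This account rests on a few compounds, and the source may have more. Where it says the series, first, only, none or still open, it means among the compounds named here.

Measured to date in an assay on isolated protein with malate dehydrogenase, mitochondrial (Sus scrofa) as the target; a higher number here means a weaker inhibitor, a lower number a stronger inhibitor:
compound 1 `O=C(O)c1cnc2cc(OCc3c(Cl)c(Cl)c(Cl)c(Cl)c3Cl)ccc2c1O` gives 4790 nM
compound 2 `O=C(O)c1cnc2cc(S(=O)(=O)O)ccc2c1O` gives 2140000 nM
compound 3 `CN(C)c1ccc2c(O)c(C(=O)O)cnc2c1` gives 479000 nM

Compound 3 stands second highest of the three numbers in this assay. Its nearest neighbour is compound 2, separated by a 4.5-fold lower number from compound 2 to compound 3 (0.65 log units; beyond the scatter); compound 3 at 479000 nM lies far above compound 1 at 4790 nM. Compound 4 `CC(=O)c1ccc2c(O)c(C(=O)O)cnc2c1` is not yet measured. It differs from compound 3 in one place: acetyl in place of dimethylamino on an aromatic carbon. Among the compounds with values here, no measured step involves acetyl. Within the data shown here, the only step at this aromatic carbon is a 4.5-fold lower number from compound 2 to compound 3 (0.65 log units; beyond the scatter), a modest shift between two unrelated groups, and the gap to compound 1 shows a large move only with a far larger group. For compound 4 a small shift at most is expected, a 1.2-fold lower number from compound 3 to compound 4 (0.08 log units; within the scatter). The estimate for compound 4 in this assay is 400000 nM, ranging from 100000 nM to 1500000 nM.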

Compound 4, half-maximal inhibitory concentration: 912000 nM
Compound 4: middle estimate off by 2.3-fold (0.36 log units), on the low side; the range from low to high includes it.
By their numbers in this assay, from the lowest: compound 1; then compounds 3 and 4 (each within the scatter of the next); then compound 2.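

In this assay, acetyl in place of dimethylamino on this aromatic carbon gives a step within the scatter (a 1.9-fold higher number from compound 3 to compound 4 (0.28 log units; within the scatter)), so these two groups are not separated here. Acetyl in place of sulfo gives a modest step beyond the scatter (a 2.3-fold lower number from compound 2 to compound 4 (0.37 log units; beyond the scatter)), so sulfo now stands apart from both of the other small groups at this carbon. No measured evidence bears on these steps. Still open, as far as these compounds go, is whether a primary amine or a plain benzyloxy group here would stay with compounds 3 and 4 or approach compound 1 (4790 nM).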